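The source may hold more compounds than are shown below. What is called first, only, known or untested is meant among the compounds shown, and "the series" means these compounds.

Measured compounds:

- Compound 1, `COc1ccncc1OC[C@@H]1CCCN1`: 613 nM
- Compound 2, `Oc1cccc(OC[C@@H]2CCCN2)c1`: 407 nM
- Compound 3, `COc1ncccc1OC[C@@H]1CCCN1`: 8960 nM

All three were tested in an assay on cell membranes for displacement of a labelled ligand from Neuronal acetylcholine receptor; alpha4/beta2 (Rattus norvegicus), read by scintillation counting; a lower number here means a stronger inhibitor, a higher number a weaker inhibitor. Within this small set compound 3 gives the highest number, with 8960 nM, which makes it the weakest binder of the three. Compound 1 is its nearest neighbour in value, and the gap between them lies well beyond the usual scatter of such measurements; compound 2 lies further still. So compound 3 starts from a clearly weak position.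

Compound 4, `COc1ncccc1OC[C@@H]1CCCN1C`, has not yet been measured. It differs from compound 3 in one place: methyl in place of hydrogen on an amine nitrogen in a ring. That is, a methyl takes the place of hydrogen on an amine nitrogen in a ring of the five-membered non-aromatic ring.

Among the compounds with values here, no measured pair in this set shows this particular change, so there is no directly comparable step to lean on. Based only on the general behaviour of small additions of this kind, the step from compound 3 to compound 4 is expected to be modest and towards a higher number, estimated as a 2.2-fold higher number from compound 3 to compound 4 (0.35 log units; beyond the scatter). For compound 4 the expected value in this assay is therefore 20000 nM, with a likely range from 6000 nM to 60000 nM.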

Compound 4, inhibition constant: 7280 nM
The estimate for compound 4 lay 2.7-fold (0.44 log units) above the measured number, and the stated range covers the measured number.
By their numbers in this assay, from the lowest: compounds 2 and 1 (each within the scatter of the next); then compounds 4 and 3 (each within the scatter of the next).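

Placing a methyl where hydrogen stood on the amine nitrogen in the ring, next to the ring atom that bears a large group, gives in this assay a step that cannot be told apart from repeat-measurement noise (a 1.2-fold lower number from compound 3 to compound 4 (0.09 log units; within the scatter)). Within the data shown here, this is the first single-place comparison in the set, and it shows that, on this core, the nitrogen can carry either hydrogen or methyl with no readable difference in this measurement. No measured information on hand accounts for this result.

The compounds shown leave open whether a larger group on the same nitrogen, such as an ethyl, a longer propyl chain or a benzyl, would also leave the number within the scatter or would shift it clearly in one direction. Among these compounds, they also leave open whether the same methyl would give an equally small step on the cores of compound 1 and compound 2, so the finding holds for the single pair formed by compound 3 and compound 4.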